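Amide substituent change in a lipopeptide series: compound 2 to 3

This account rests on a few compounds, and the source may have more. Where it says the series, first, only, none or still open, it means among the compounds named here.

Measured compounds:
compound 1 `CCCCCCCCCCCC(=O)OC[C@H](CSC[C@@H](N)C(=O)NCCCCCCO)OC(=O)CCCCCCCCCCC`: 33 nM
compound 2 `CCCCCCCCCCCC(=O)OC[C@H](CSC[C@@H](N)C(=O)NC(C)c1ccc(O)cc1)OC(=O)CCCCCCCCCCC`: 2890 nM

In an assay on HEK293 cells for agonist activity at Toll-like receptor 2 (Homo sapiens) (a lower number here means that less compound is needed, a higher number that more compound is needed for the effect), compound 2 gives 2890 nM and holds the highest number of the two measured compounds. Within the data shown here, its nearest neighbour is compound 1, which in this assay gives 33 nM; the one measured step, an 88-fold higher number from compound 1 to compound 2 (1.94 log units; beyond the scatter), is large and beyond the scatter, and corresponds to 1-(4-hydroxyphenyl)ethyl in place of 6-hydroxyhexyl on the amide-type nitrogen.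

Compound 3 `CCCCCCCCCCCC(=O)OC[C@H](CSC[C@@H](N)C(=O)NC(C)CCC(C)C)OC(=O)CCCCCCCCCCC` is not yet measured. It differs from compound 2 by isopentyl in place of 4-hydroxyphenyl on a saturated chain carbon bound to an amide-type nitrogen and a saturated chain carbon. Among the measured compounds shown here, no measured step covers this exact change. For the measured compounds named here, the only step that bears on it is the one from compound 1 to compound 2, where the move from a hydroxy-bearing chain to a ring with the same donor and acceptor count costs a large factor. Compound 3 returns to a chain without a ring, but also drops the hydroxyl that compound 1 carries, so only part of that loss is expected to be recovered. A step toward a lower number is expected, a 4.8-fold lower number from compound 2 to compound 3 (0.68 log units; beyond the scatter), with wide uncertainty. Compound 3 is therefore estimated at 600 nM in this assay, within 100 nM to 3500 nM.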

Compound 3, half-maximal effective concentration: 190 nM
Estimate against measurement, compound 3: 3.2-fold (0.50 log units) above; measured number inside the range.
By their numbers in this assay, from the lowest: compound 1; then compound 3; then compound 2.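

In this assay, replacing 4-hydroxyphenyl with isopentyl on the saturated chain carbon gives a 15-fold lower number from compound 2 to compound 3 (1.18 log units; beyond the scatter), so a substituent with no ring recovers much of the ground lost in the earlier step to the ring-bearing compound 2, even though isopentyl has no hydrogen-bond donor or acceptor. The hydroxyl is thus not needed for a number well under that of compound 2, yet the all-carbon branched substituent does not fully match the hydroxy-bearing chain: 1,4-dimethylpentyl in place of 6-hydroxyhexyl gives a 5.8-fold higher number from compound 1 to compound 3 (0.76 log units; beyond the scatter), a modest step compared with the large one between the two ring-free and ring-bearing partners. The compounds at hand offer no independent data to explain either step.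

The step to 1,4-dimethylpentyl changes the terminal hydroxyl and the chain branching together, so a straight hexyl chain or a 6-aminohexyl group would be needed to tell these two contributions apart. Equally open, as far as these compounds go, is whether a plain phenyl ring behaves like 4-hydroxyphenyl, and whether a longer chain or a terminal carboxylic acid is accepted at this amide nitrogen.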